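Adding a methyl to a thiosemicarbazide glioma inhibitor

The source may hold more compounds than are shown below. What is called first, only, known or untested is meant among the compounds shown, and "the series" means these compounds.

Two measured compounds frame this study. Compound 1 `COc1cc(C(=O)NNC(=S)Nc2csc(-c3ccc(C)cc3)c2)cc(OC)c1OC` and compound 2 `COc1cc(OC)cc(C(=O)NNC(=S)Nc2csc(-c3ccccc3)c2)c1` share a core and differ in their substitution elsewhere; in a functional assay on Hs 683 cells (Homo sapiens) for inhibition, read by colorimetric assay and MTT assay, with a stated time of 72 h (on this read-out lower numbers stand for stronger inhibition and higher numbers for weaker inhibition), compound 1 gives 42000 nM, and in this assay compound 2 gives 42000 nM. Compound 2 therefore stands level with compound 1 at the digits shown, a difference within the usual scatter. The unmeasured compound 3 `COc1cc(OC)cc(C(=O)NNC(=S)Nc2csc(-c3ccc(C)cc3)c2)c1` is reached from compound 2 by one change: methyl in place of hydrogen on an aromatic carbon. Compound 1 already carries the same methyl on its ring and sits where compound 2 sits, so the change is expected to move the read-out of compound 3 not beyond the scatter, as the estimated step of no change at the digits printed from compound 2 to compound 3 (within the scatter) states. The estimated value for compound 3 in this assay is 42000 nM, expected within 20000 nM to 90000 nM.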

Compound 3, half-maximal inhibitory concentration: 37000 nM
For compound 3 the middle estimate is 1.1-fold (0.06 log units) above the measured one; the measured number falls inside the stated range.
By their numbers in this assay, from the lowest: compounds 3, 1 and 2 (each within the scatter of the next).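

In this assay the change from phenyl to 4-methylphenyl gives a 1.1-fold lower number from compound 2 to compound 3 (0.06 log units; within the scatter) and so this position, para to a large group, takes a methyl on its aromatic carbon with no difference that can be told from the scatter. With the 4-methylphenyl held in both compounds, hydrogen in place of methoxy on an aromatic carbon gives a 1.1-fold lower number from compound 1 to compound 3 (0.06 log units; within the scatter) and thus also leaves the read-out within the scatter, so neither single change separates these compounds. Nothing is available here that could explain why these numbers stay together.

The compounds shown leave open whether a different group at this place, such as an amine, a hydroxyl or a carboxylic acid, would give a step beyond the scatter. On these data alone, a longer chain in place of the methyl, such as propyl, also remains open.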